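Swapping the aryl group on the triazole nitrogen

The source may report more compounds than this note shows. Statements on the series, on what has been measured and on what is new or still open speak of the compounds shown alone.

Among the measured compounds shown here, compound 1 `Oc1cc(C(F)(F)F)ccc1-c1nc(-c2ccccc2O)n(-c2ccc(Br)cc2)n1` is the stronger of the two compounds measured so far: in a toxicity assay on HaCaT cells (Homo sapiens) for cytotoxicity, read by MTT assay (a lower number here means a stronger inhibitor, a higher number a weaker inhibitor), compound 1 gives 29600 nM, while compound 2 `Cc1cc(C)cc(-n2nc(-c3ccc(C(F)(F)F)cc3O)nc2-c2ccccc2O)c1` gives 127000 nM. For the measured compounds named here, the one step known at this position, a 4.3-fold higher number from compound 1 to compound 2 (0.63 log units; beyond the scatter), came from putting 3,5-dimethylphenyl in place of 4-bromophenyl on an aromatic nitrogen. Compound 3 `Oc1cc(C(F)(F)F)ccc1-c1nc(-c2ccccc2O)n(-c2cc(F)cc(F)c2)n1` differs from compound 1 in the same place: 3,5-difluorophenyl in place of 4-bromophenyl on an aromatic nitrogen. Going by the values given here, the only step that bears on this change is the one from compound 1 to compound 2, which was modest and upward. Since compound 3 also carries a 3,5-disubstituted phenyl there, a weaker effect than in compound 1 is expected, but smaller, because a 4.3-fold higher number from compound 1 to compound 2 (0.63 log units; beyond the scatter) involved a different pair of substituents. Compound 3 is therefore estimated at 55000 nM, in the range 25000 nM to 130000 nM, a step of a 1.9-fold higher number from compound 1 to compound 3 (0.27 log units; within the scatter) expected to be at the edge of the scatter.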

Compound 3, half-maximal inhibitory concentration: 45400 nM
Beside the measured number, compound 3's estimate is 1.2-fold (0.08 log units) above it; measured number inside the range.
By their numbers in this assay, from the lowest: compounds 1 and 3 (each within the scatter of the next); then compound 2.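

In this assay, 3,5-difluorophenyl and 4-bromophenyl cannot be told apart on this aromatic nitrogen, with a 1.5-fold higher number from compound 1 to compound 3 (0.19 log units; within the scatter). Swapping 3,5-dimethylphenyl for 3,5-difluorophenyl, however, gives a 2.8-fold lower number from compound 2 to compound 3 (0.45 log units; beyond the scatter), so compound 2 and compound 3 show that having two substituents on this phenyl ring does not by itself set the number: the identity of those substituents matters here. Nothing available explains why fluorine and methyl differ in this way.

The compounds shown leave open how an amine, a methoxy group or a carboxylic acid on this phenyl ring would read in this assay. They also leave open whether the aromatic ring itself is needed, which a cyclohexyl group or a short alkyl chain on the same nitrogen could test.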